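The source may report more compounds than this note shows. Statements on the series, on what has been measured and on what is new or still open speak of the compounds shown alone.

Among the compounds with values here, compound 1 `COc1cc(C)c(-c2cccc(COc3ccc(S(=O)(=O)CC(=O)O)cc3)c2)c(C)c1` has the lowest of the two numbers measured so far: in a functional assay on CHO cells for agonist activity at Free fatty acid receptor 1 (Homo sapiens), read by FLIPR and calcium flux (a higher number here means that more compound is needed for the effect, a lower number that less compound is needed), compound 1 gives 57.5 nM. Compound 2 `COc1cc(C)c(-c2cccc(COc3ccc4c(c3)SCC4CC(=O)O)c2)c(C)c1` gives 123 nM in this assay, a gap beyond the scatter. Compound 3 `Cc1cc(OCC(C)C)cc(C)c1-c1cccc(COc2ccc(S(=O)(=O)CC(=O)O)cc2)c1` differs from compound 1 by one change: isopropyl in place of hydrogen on a saturated chain carbon bound to an oxygen on an aromatic ring. Within the data shown here, no pair of measured compounds shows this change, so its effect is unknown from these data. The step from compound 1 to compound 3 is expected to be small, a 1.3-fold lower number from compound 1 to compound 3 (0.11 log units; within the scatter), within or just beyond the scatter and in either direction. Compound 3 is therefore estimated at 45 nM, with a likely range of 12 nM to 170 nM.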

Compound 3, half-maximal effective concentration: 95.5 nM
For compound 3 the middle estimate is 2.1-fold (0.33 log units) below the measured one; measured number inside the range.
By their numbers in this assay, from the lowest: compounds 1, 3 and 2 (each within the scatter of the next, the first and the last beyond it).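

Isopropyl in place of hydrogen on a saturated chain carbon bound to an oxygen on an aromatic ring gives, in this assay, a 1.7-fold higher number from compound 1 to compound 3 (0.22 log units; within the scatter). On this one pair, then, methoxy can give way to isobutoxy without a change that stands clear of the scatter. Nothing available explains the size of this step.

As far as these compounds go, it remains open whether a longer chain, a cyclopropylmethyl group or an amine at this place would also stay within the scatter. Whether the same change behaves alike on the core of compound 2 is open too.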